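The source may report more compounds than this note shows. Statements on the series, on what has been measured and on what is new or still open speak of the compounds shown alone.

Compound 2 `N#Cc1cnc(NCc2cnccc2C(F)(F)F)cc1N[C@H]1CC[C@@H](O)CC1` gives 6% in an ADME assay on S9 fraction from liver (Rattus norvegicus) for metabolic stability, with a stated time of 1 h (a lower number here means that less of the compound is left, a higher number that more of the compound is left), the lowest of the two numbers measured. Compound 1 `N#Cc1cnc(NCc2cnccc2C(F)(F)F)cc1N[C@H]1C[C@@H](O)C1` gives 70%, and the step of a number 64 percentage points lower from compound 1 to compound 2 (beyond the scatter) shows that a change on the ring at this nitrogen can move the read-out a great deal. Compound 3 `N#Cc1cnc(NCc2cnccc2C(F)(F)F)cc1N[C@H]1CC[C@@H](c2nc[nH]n2)CC1` differs from compound 2 by 1H-1,2,4-triazol-3-yl in place of hydroxy on a saturated ring carbon. Among the measured compounds shown here, no measured step swaps the hydroxy for another group, so nothing measured bears directly on this change. Compound 2 already stands near the bottom of the scale. For compound 3 a step of a number 9 percentage points higher from compound 2 to compound 3 (within the scatter) is expected, meaning no shift beyond the scatter or at most a small rise. The estimate for compound 3 is 15%, within 2% to 45%.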

Compound 3, percent of the compound remaining: 29%
Beside the measured number, compound 3's estimate is 14 percentage points below it; low and high end bracket the measured number.
By their numbers in this assay, from the lowest: compound 2; then compound 3; then compound 1.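

Replacing hydroxy with 1H-1,2,4-triazol-3-yl gives, in this assay, a number 23 percentage points higher from compound 2 to compound 3 (beyond the scatter). The earlier step changed the size of the saturated ring, whereas this one keeps the six-membered ring and changes the group on its carbon, showing that this place also affects how much compound is left. A group of five heavy atoms is tolerated here in place of one, and the read-out does not fall. On these data alone, whether an amine, a carboxylic acid or another five-membered aromatic ring at this carbon would give a similar rise remains open. Nothing available explains the rise seen with the 1H-1,2,4-triazol-3-yl group.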